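Amide substituent swap on the spiro core series

A few compounds are considered here, and "the series" means these few. Any claim that something is new, unique, unknown or untested is made for them only; others in the source may bear on it.

Three analogues share one core and differ only in the group on the carbonyl carbon of the side-chain amide. Compound 1 `CCOC(=O)C1CCN(C(=O)CN2CN(c3ccccc3)C3(CCN(C(=O)c4ccc(C(C)(C)C)cc4)CC3)C2=O)CC1` gives 3100 nM in an assay on HEK293 cells for displacement of a labelled ligand from NPC1-like intracellular cholesterol transporter 1 (Homo sapiens); on this read-out higher numbers stand for weaker inhibition and lower numbers for stronger inhibition. Compound 2 `CC(C)(C)c1ccc(C(=O)N2CCC3(CC2)C(=O)N(CC(=O)N2CCN(S(C)(=O)=O)CC2)CN3c2ccccc2)cc1` gives 19000 nM in this assay, and compound 3 `CCOC(=O)C1CCCN(C(=O)CN2CN(c3ccccc3)C3(CCN(C(=O)c4ccc(C(C)(C)C)cc4)CC3)C2=O)C1` gives 8200 nM. Compound 3 therefore stands second highest of the three numbers, nearer to compound 2 than to compound 1.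

The steps at this position are all modest: a 6.1-fold higher number from compound 1 to compound 2 (0.79 log units; beyond the scatter), a 2.6-fold higher number from compound 1 to compound 3 (0.42 log units; beyond the scatter) and a 2.3-fold lower number from compound 2 to compound 3 (0.36 log units; beyond the scatter). Each one exchanges a whole ring-bearing group for another, and none moves the number by more than a small multiple.

Compound 4 `CC(C)(C)c1ccc(C(=O)N2CCC3(CC2)C(=O)N(CC(=O)NCN)CN3c2ccccc2)cc1` is the next change at the same place: (aminomethyl)amino in place of 3-(ethoxycarbonyl)piperidin-1-yl on a carbonyl carbon. This removes the ring and the ester entirely and brings in two hydrogen-bond donors. Among the measured compounds shown here, none of the measured steps covers so small an entering group, so the only guide is that changes here have so far been modest, and that the largest loss came with the ring-bearing group of compound 2. A modest weakening is expected, so for compound 4 the estimate is 20000 nM with a range of 6000 nM to 60000 nM, which means an expected step of a 2.4-fold higher number from compound 3 to compound 4 (0.39 log units; beyond the scatter).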

Compound 4, half-maximal inhibitory concentration: 26500 nM
Compound 4: the middle estimate sits 1.3-fold (0.12 log units) below what was measured; the measured number falls inside the stated range.
By their numbers in this assay, from the lowest: compound 1; then compound 3; then compounds 2 and 4 (each within the scatter of the next).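

Replacing the whole 3-(ethoxycarbonyl)piperidin-1-yl group with the ring-free (aminomethyl)amino group gives, in this assay, a 3.2-fold higher number from compound 3 to compound 4 (0.51 log units; beyond the scatter), and the comparison with the other ester gives an 8.5-fold higher number from compound 1 to compound 4 (0.93 log units; beyond the scatter), the largest step yet seen at this position, though still modest. The comparison with the sulfonyl-bearing group gives a 1.4-fold higher number from compound 2 to compound 4 (0.14 log units; within the scatter), so a ring is not needed to reach the level of compound 2, and among these compounds only the two ester-bearing piperidines, compound 1 and compound 3, give numbers lower than compound 4 by more than the scatter. No independent measurement bears on why these steps take the size they do.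

Compound 4 loses the ring and the ester in one change, so the compounds shown do not separate their contributions; an unsubstituted piperidin-1-yl group would test the ring without the ester, while an open-chain ethyl ester would test the ester without the ring. Going by these compounds, a carboxylic acid in place of the ethyl ester on the piperidine also remains open, as does a simple primary amide, which would show how far the number moves with a still smaller group on the carbonyl carbon.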